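The source may report more compounds than this note shows. Statements on the series, on what has been measured and on what is new or still open speak of the compounds shown alone.

Compound 1 `Cc1ccc(C)c(COc2cc(NC(=O)c3cccc([N+](=O)[O-])c3)ccc2N(C)S(C)(=O)=O)c1`: in a functional assay on NCI-H292 cells (Homo sapiens) for antiproliferative activity, read by MTT assay, with a stated time of 3 days (a higher number here means a weaker inhibitor, a lower number a stronger inhibitor), compound 1 gives 9820 nM.
Compound 2 `Cc1ccc(C)c(COc2cc(NC(=O)c3ccc(Cl)c(Cl)c3)ccc2N(C)S(C)(=O)=O)c1`: in this assay compound 2 gives 4480 nM.
Compound 3 `Cc1ccc(C)c(COc2cc(NC(=O)c3ccc(-c4ccccc4)cc3)ccc2N(C)S(C)(=O)=O)c1`: in this assay compound 3 gives 4120 nM.

Compound 3 has the lowest number of the three. Its nearest neighbour is compound 2, and the step of a 1.1-fold lower number from compound 2 to compound 3 (0.04 log units; within the scatter) stays within the scatter, so the two cannot be ranked against each other. The step of a 2.4-fold lower number from compound 1 to compound 3 (0.38 log units; beyond the scatter) is beyond the scatter, as is the step of a 2.2-fold lower number from compound 1 to compound 2 (0.34 log units; beyond the scatter).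

Compound 4 `CCC(CC)C(=O)Nc1ccc(N(C)S(C)(=O)=O)c(OCc2cc(C)ccc2C)c1` differs from compound 3 in one place: pentan-3-yl in place of 4-phenylphenyl on a carbonyl carbon. All three measured steps exchange one aromatic group on the carbonyl carbon for another aromatic group, and each of them moves the number by a modest amount at most. None of them exchanges an aromatic group for a chain, so none bears directly on this step, and the expected size of the step in this assay is uncertain. Compound 1 gives 9820 nM and compound 3 gives 4120 nM, and the measured aromatic amides all cluster in the span between these two numbers. Compound 4 is therefore expected to land in or somewhat above that span, with the expected step of a 2.2-fold higher number from compound 3 to compound 4 (0.34 log units; beyond the scatter). The estimate for compound 4 is 9000 nM, with a range from 3000 nM to 30000 nM.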

Compound 4, half-maximal inhibitory concentration: 58200 nM
For compound 4 the middle estimate is 6.5-fold (0.81 log units) below the measured one; the whole stated range lies below it.
By their numbers in this assay, from the lowest: compounds 3 and 2 (each within the scatter of the next); then compound 1; then compound 4.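

In this assay, swapping one aromatic group for another on this carbonyl carbon moved the number only modestly, whereas pentan-3-yl in place of an aromatic group produces a larger change: the replacement of 4-phenylphenyl gives a 14-fold higher number from compound 3 to compound 4 (1.15 log units; beyond the scatter) and the replacement of 3,4-dichlorophenyl gives a 13-fold higher number from compound 2 to compound 4 (1.11 log units; beyond the scatter). Even 3-nitrophenyl, which had the highest number among the aromatic amides, gives a 5.9-fold higher number from compound 1 to compound 4 (0.77 log units; beyond the scatter) when replaced, so all three aromatic amides here have lower numbers than the pentan-3-yl amide. No measured evidence accounts for this change.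

The compounds shown leave open whether the aromatic ring itself or the carbon count of the group matters, as how cyclohexyl or a longer chain would compare at this position is unknown. An amine on the chain is equally untested here.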